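From compound 1 to compound 4: adding a benzoyl group

The source may hold more compounds than are shown below. What is called first, only, known or untested is meant among the compounds shown, and "the series" means these compounds.

Measured so far in a functional assay on L1210 cells (Mus musculus) for inhibition (on this read-out lower numbers stand for stronger inhibition and higher numbers for weaker inhibition), each value a limit:
compound 1 `C#CCN(Cc1ccc2nc(C)nc(O)c2c1)c1ccccc1`: > 6500 nM
compound 2 `C#CCN(Cc1ccc2nc(C)nc(O)c2c1)c1cccc(C(C)O)c1`: > 49000 nM
compound 3 `C#CCN(Cc1ccc2nc(C)nc(O)c2c1)c1cccc(C(F)(F)F)c1`: > 2200 nM

Compound 1 stands at a limit, > 6500 nM, and not at a number. For the measured compounds named here, compound 2 and compound 3 are also known only as limits, so no measured compound offers an exact reference point in this assay.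

Compound 4 `C#CCN(Cc1ccc2nc(C)nc(O)c2c1)c1ccc(C(=O)c2ccccc2)cc1` differs from compound 1 in one place: benzoyl in place of hydrogen on an aromatic carbon. Two other replacements of hydrogen on an aromatic carbon bear on this change. One is a step that the two limits leave unreadable from compound 1 to compound 2, and the other is a step that the two limits leave unreadable from compound 1 to compound 3. Neither shows a size or a direction, and neither involves benzoyl. No step beyond the scatter is therefore expected, and a further limit would be no surprise.

The expected step is a step that the limit leaves unreadable from compound 1 to compound 4. Compound 4 is estimated at 8000 nM, with an expected range of 2000 nM to 40000 nM.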

Compound 4, half-maximal inhibitory concentration: 7700 nM
The estimate for compound 4 lay 1.0-fold (0.02 log units) above the measured number; low and high end bracket the measured number.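

In this assay compound 4 gives 7700 nM. For the compounds shown here, compound 1 gives only a limit, > 6500 nM, so no step from it to compound 4 can be read. On these data alone, whether benzoyl in place of hydrogen on an aromatic carbon strengthens or weakens inhibition, and by how much, remains open.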